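A few compounds are considered here, and "the series" means these few. Any claim that something is new, unique, unknown or untested is made for them only; others in the source may bear on it.

Three compounds share one core and differ in what hangs from the amide. Compound 1 `O=C(CCCc1ccccc1)Nc1nc2ccsc2c(=O)s1` carries a three-carbon chain ending in phenyl on a core with a thiophene-fused ring, and in an assay on mitochondria (strain Sprague-Dawley) for inhibition of Amine oxidase [flavin-containing] B (Rattus norvegicus), read by fluorescence and Amplex Red, with stated times of 30 min and 45 min (a higher number here means a weaker inhibitor, a lower number a stronger inhibitor), compound 1 gives 298 nM. Compound 2 `O=C(CCc1ccccc1)Nc1nc2ccccc2c(=O)s1` has a shorter two-carbon chain to phenyl on a benzo-fused core, and in this assay compound 2 gives 42.7 nM. Compound 3 `COc1cccc(CCCC(=O)Nc2nc3ccccc3c(=O)s2)c1` has the longer chain again, ending in a phenyl bearing methoxy, and in this assay compound 3 gives 1300 nM. Compound 2 thus has the lowest number of the three, a gap beyond the usual scatter to both others.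

Compound 4 `O=C(CCc1ccccc1Br)Nc1nc2ccccc2c(=O)s1` keeps everything of compound 2 and changes one spot: bromo in place of hydrogen on an aromatic carbon, placed ortho to a large group. Among the compounds with values here, no measured pair shows the effect of such a bromo in this assay, so there is nothing to lean on beyond the starting point. The step from compound 2 to compound 4 is expected to be a 1.3-fold higher number from compound 2 to compound 4 (0.11 log units; within the scatter), perhaps no larger than the scatter. Compound 4 is therefore estimated at 55 nM, with a range from 15 nM to 220 nM.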

Compound 4, half-maximal inhibitory concentration: 64 nM
For compound 4 the middle estimate is 1.2-fold (0.07 log units) below the measured one; measured number inside the range.
By their numbers in this assay, from the lowest: compounds 2 and 4 (each within the scatter of the next); then compound 1; then compound 3.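

Within the data shown here, this pair gives the first direct reading of a single change at this spot: in this assay, putting bromo in place of hydrogen on an aromatic carbon, ortho to a large group, gives a 1.5-fold higher number from compound 2 to compound 4 (0.18 log units; within the scatter). Going from phenyl to 2-bromophenyl therefore adds a heavy atom at this position without a change that can be told apart from the scatter, so this position accepts bromo in this assay. Nothing available here offers a measured explanation for this result.

Going by these compounds, whether this position would accept a group of a different kind, such as a fluoro, an amine or a carboxylic acid, remains open. Also open, on these data alone, is whether bromo on another carbon of this ring, or on a compound with the three-carbon chain, would give a similarly small step.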